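The compounds below may be only part of what the source reports. "The series", "measured", "known", "first", "only" and "open" are said of these compounds alone.

For the measured compounds named here, in a functional assay on ECa-109 cells for inhibition, with ECa-109 cell line (Homo sapiens) as the target, read by sulforhodamine B assay (on this read-out higher numbers stand for weaker inhibition and lower numbers for stronger inhibition), the series so far gives limits only, with no numbers. Compound 1 `CCc1ccc(NC2=CC(=O)c3c(nc4n3[C@H]3OC[C@@H](O)[C@H]3OC4)C2=O)cc1` reads > 4000 nM, which is a limit. Compound 2 `O=C1C(N2CCC2)=CC(=O)c2c1nc1n2[C@H]2OC[C@@H](O)[C@H]2OC1` reads > 16000 nM, also a limit. Compound 3 `O=C1C(NCc2ccccc2)=CC(=O)c2c1nc1n2[C@H]2OC[C@@H](O)[C@H]2OC1` reads > 8000 nM, again a limit, so it cannot be placed in any order against the other two.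

The change to compound 4 `CCCN(CCC)C1=CC(=O)c2c(nc3n2[C@H]2OC[C@@H](O)[C@H]2OC3)C1=O` is dipropylamino in place of benzylamino on a double-bonded ring carbon.

Three measured steps change the group at this carbon: a step that the two limits leave unreadable from compound 1 to compound 3, a step that the two limits leave unreadable from compound 2 to compound 3 and a step that the two limits leave unreadable from compound 1 to compound 2. None has a readable size, so none supplies a size or direction to carry over. Going by the values given here, all three groups tried at this carbon ended in a limit, and no measured compound goes against that.

Compound 2 is the nearest guide for a group without a ring of carbon only, and its limit is > 16000 nM. On that basis, another limit is the likeliest report for compound 4.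

The expected step is a step that the limit leaves unreadable from compound 3 to compound 4, with no change beyond the scatter expected in this assay. Compound 4 is estimated at 12000 nM, with an expected range from 5000 nM to 30000 nM.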

Compound 4, half-maximal inhibitory concentration: > 16000 nM
Compound 4 ended at the assay's limit (the forecaster's own chance of this, stated with the estimate: 80%); middle value at least 1.3-fold (0.12 log units) from the limit.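

Compound 4 reads > 16000 nM, which is a limit. For the compounds shown here, all four values are limits, so no step from compound 1, compound 2 or compound 3 to compound 4 can be read. The compounds shown leave open how strongly any of them inhibits in this assay, and whether the group on the double-bonded ring carbon changes that at all.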